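Dibromoalkene to terminal alkyne on two pyran-type cores

The source may hold more compounds than are shown below. What is called first, only, known or untested is meant among the compounds shown, and "the series" means these compounds.

Measured so far in a functional assay on WiDr cells (Homo sapiens) for antiproliferative activity; on this read-out lower numbers stand for stronger inhibition of growth and higher numbers for weaker inhibition of growth:
compound 1, `C[C@@H]1O[C@H](CCC=C(Br)Br)C([Si](C)(C)C)=C(Cl)[C@H]1C`: 25000 nM
compound 2, `C#CCC[C@H]1O[C@@H](C)[C@H](C)C(Cl)=C1[Si](C)(C)C`: 24000 nM
compound 3, `ClC1=CC(CCC=C(Br)Br)OCC1`: 23000 nM

The three numbers sit close together. Compound 3 gives the lowest of them, but its gap to compound 2 and to compound 1 lies within the scatter, so no order among the three can be drawn from this assay.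

Compound 1 and compound 2 share a core and differ in one place: ethynyl in place of 2,2-dibromoethenyl on a saturated chain carbon, two bonds along the chain from a saturated ring carbon. The step this change made is a 1.0-fold lower number from compound 1 to compound 2 (0.02 log units; within the scatter), which is to say that swapping the dibromoalkene for the terminal alkyne left the growth-inhibiting concentration where it was.

Compound 4, `C#CCCC1C=C(Cl)CCO1`, is not yet measured. It stands to compound 3 as compound 2 stands to compound 1: ethynyl in place of 2,2-dibromoethenyl on a saturated chain carbon, two bonds along the chain from a saturated ring carbon. The place lines of the two changes read the same word for word, so this is the same change on a second core. How the core of compound 3 differs from the core of compound 1 is not broken down here.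

Among the compounds with values here, with only one earlier instance to go on, the expectation for compound 4 rests on the flat step of compound 1 to compound 2, a 1.0-fold lower number from compound 1 to compound 2 (0.02 log units; within the scatter), carried over to compound 3 with its value 23000 nM. Compound 4 is therefore expected to show a step of no change at the digits printed from compound 3 to compound 4 (within the scatter) in this assay. The estimate for compound 4 is 23000 nM, with a range of 11000 nM to 48000 nM.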

Compound 4, concentration for 50% growth inhibition: > 100000 nM
Compound 4: a limit, no number (the forecaster's own chance of this, stated with the estimate: 15%); middle value at least 4.3-fold (0.63 log units) away from the limit.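

In this assay the swap of 2,2-dibromoethenyl for ethynyl gives an at least 4.3-fold higher number from compound 3 to compound 4 (0.63 log units; beyond the scatter), so the flat result seen on the core of compound 1 does not carry over to the core of compound 3: the same change on two cores in this assay, a 1.0-fold lower number (0.02 log units; within the scatter) from compound 1 to compound 2 and an at least 4.3-fold higher number (0.63 log units; beyond the scatter) from compound 3 to compound 4, at least 4.5-fold (0.65 log units) apart, beyond the scatter of two such steps.
Compound 4 gives > 100000 nM, which is a limit of the assay and not a number, so the step has a floor but no measured size: the limit of > 100000 nM in this assay, at which 1 of the 4 values shown sits.
This shows that, across these two cores, the outcome of the change depends on the core; it does not show which feature of the cores is responsible, and two cores give no rule for a third.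

The compounds shown leave open which of the differences between the core of compound 1 and the core of compound 3 accounts for the split, as no compound separates those differences one at a time. Also open, on these data alone, is whether the loss of growth inhibition on the core of compound 3 is specific to ethynyl, or whether a nitrile, a carboxylic acid or a longer chain ending in ethynyl on that core would read the same way.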